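Removing Substituents from the Benzyl Arm: Compound 4

The source may report more compounds than this note shows. Statements on the series, on what has been measured and on what is new or still open speak of the compounds shown alone.

In an assay on isolated protein for displacement of a labelled ligand from Orexin/Hypocretin receptor type 1 (Homo sapiens), with a stated time of 90 min (a lower number here means a stronger inhibitor, a higher number a weaker inhibitor), compound 1 `COc1cc(F)c(CN2C(=O)N(c3cc(OC)nc(OC)c3)S(=O)(=O)c3ccccc32)c(F)c1` gives 1 nM, compound 2 `COc1cc(F)c(CN2C(=O)N(c3ccc(OC)c(OC)c3)S(=O)(=O)c3ccccc32)c(F)c1` gives 2 nM, and compound 3 `COc1cc(N2C(=O)N(Cc3c(F)cc(F)cc3F)c3ccccc3S2(=O)=O)ccn1` gives 398 nM. Compound 2 thus stands second highest of the three numbers, close to compound 1 and far from compound 3. Among the compounds with values here, the only step measured in one place, a 2.0-fold higher number from compound 1 to compound 2 (0.30 log units; within the scatter), alters the group on the amide-type nitrogen in the ring, not the benzyl group, so it does not bear directly on the change made here. Compound 4 `COc1ccc(N2C(=O)N(Cc3ccccc3)c3ccccc3S2(=O)=O)cc1OC` carries phenyl in place of 2,6-difluoro-4-methoxyphenyl on a saturated chain carbon bound to an amide-type nitrogen in a ring. Within the data shown here, no measured step changes this group alone; compound 3, which differs from compound 2 in its benzyl group and elsewhere too, simply shows a much higher number. A clear loss is therefore expected, namely a 30-fold higher number from compound 2 to compound 4 (1.48 log units; beyond the scatter). Compound 4 is expected to give 60 nM, within 10 nM to 400 nM.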

Compound 4, inhibition constant: 2000 nM
Compound 4: middle estimate off by 33-fold (1.52 log units), on the low side; measured number above the stated range.
By their numbers in this assay, from the lowest: compounds 1 and 2 (each within the scatter of the next); then compound 3; then compound 4.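

Within the data shown here, this is the first change measured on the benzyl arm alone: in this assay, replacing 2,6-difluoro-4-methoxyphenyl with phenyl on this saturated chain carbon causes a large loss (a 1000-fold higher number from compound 2 to compound 4 (3.00 log units; beyond the scatter)). The substituents on this ring therefore matter greatly to the number, though one step cannot separate the contribution of the fluorines from that of the methoxy group. No evidence here explains the size of this loss. From the compounds shown here alone, it remains open how much each substituent contributes alone, and whether chlorine atoms in place of the fluorines would keep the low number.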